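This account rests on a few compounds, and the source may have more. Where it says the series, first, only, none or still open, it means among the compounds named here.

Measured so far in a functional assay on HepG2 cells (Homo sapiens) for cytotoxicity, read by XTT assay, with a stated time of 72 h; a higher number here means a weaker inhibitor, a lower number a stronger inhibitor:
compound 1, `Cc1c[se]c(N/N=C/c2ccc(Cl)cc2)n1`: 56500 nM
compound 2, `CCOC(=O)c1[se]c(N/N=C/c2ccc(Cl)cc2)nc1C`: 52800 nM

For the measured compounds named here, only two compounds have numbers in this assay, and they sit at the same level: the step of a 1.1-fold lower number from compound 1 to compound 2 (0.03 log units; within the scatter) is within the scatter, so compound 1 cannot be set apart from compound 2 on these data. Both are weak inhibitors in this assay.

Compound 3, `COc1ccc(/C=N/Nc2nc(C)c[se]2)cc1`, has not been measured. It differs from compound 1 in one place: methoxy in place of chloro on an aromatic carbon. Going by the values given here, the one measured step, from compound 1 to compound 2, changes a substituent on the shared core rather than on the six-membered aromatic ring of carbon only, and it was within the scatter; it therefore gives no direct guide to the exchange of chloro for methoxy. With nothing in the measured pairs that bears on this change, the expectation is that the number for compound 3 stays near that of compound 1, with no step beyond the scatter in either direction. The expected step of a 1.0-fold lower number from compound 1 to compound 3 (0.00 log units; within the scatter) is accordingly small. For compound 3 the estimate in this assay is 56000 nM, with a range from 20000 nM to 150000 nM.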

Compound 3, half-maximal inhibitory concentration: 83200 nM
Compound 3: middle estimate off by 1.5-fold (0.17 log units), on the low side; the range from low to high includes it.
By their numbers in this assay, from the lowest: compounds 2, 1 and 3 (each within the scatter of the next).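

In this assay, for the compounds shown here, the exchange of chloro for methoxy on an aromatic carbon of the six-membered aromatic ring of carbon only gives a 1.5-fold higher number from compound 1 to compound 3 (0.17 log units; within the scatter) and is the first reading at this position, since the earlier step concerned the shared core. Replacing one chlorine atom with a group of two heavy atoms that carries a hydrogen-bond acceptor therefore leaves compound 3 at the same level as compound 1, and this exchange cannot be told apart from no effect on these data. No measurement shown here offers an explanation for this result.

The compounds shown leave open whether any group at this position can move the number beyond the scatter, for example an amine, a carboxylic acid or a longer chain such as butoxy, since chloro and methoxy are the only two substituents with readings there. They also leave open whether methoxy would give a similar reading alongside the ethoxycarbonyl group of compound 2, as no compound shown carries both groups.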